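Replacing one group on compound 2

A few compounds are considered here, and "the series" means these few. Any claim that something is new, unique, unknown or untested is made for them only; others in the source may bear on it.

compound 1 `CCCCC(CC(=O)O[C@H](CC=C(C)C)C1=CC(=O)c2c(O)ccc(O)c2C1=O)OC(C)=O` gives 67700 nM
compound 2 `CC(C)=CC[C@@H](OC(=O)C1CCCO1)C1=CC(=O)c2c(O)ccc(O)c2C1=O` gives 10500 nM

In a functional assay on DU-145 cells (Homo sapiens) for cytotoxicity, read by MTT assay (a lower number here means a stronger inhibitor, a higher number a weaker inhibitor), compound 2 gives 10500 nM as the lower of the two numbers. Compound 3 `CC(C)=CC[C@@H](OC(=O)CC(C)(O)c1ccccc1)C1=CC(=O)c2c(O)ccc(O)c2C1=O` is next. The change is 2-hydroxy-2-phenylpropyl in place of oxolan-2-yl on a carbonyl carbon and it puts 2-hydroxy-2-phenylpropyl in place of oxolan-2-yl on a carbonyl carbon. Going by the values given here, one measured step bears on this: a 6.4-fold lower number from compound 1 to compound 2 (0.81 log units; beyond the scatter) at the same place. That modest step shows the number can move with this group, but it cannot settle the direction for a new one. A similarly modest rise is therefore expected, and the estimate is a 1.4-fold higher number from compound 2 to compound 3 (0.15 log units; within the scatter) as the expected step. For compound 3 the estimated value is 15000 nM with 4000 nM to 50000 nM as its expected range.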

Compound 3, half-maximal inhibitory concentration: > 100000 nM
Compound 3 ended at the assay's limit; the forecaster's own chance of this, stated with the estimate: 10%; middle value at least 6.6-fold (0.82 log units) away from the limit.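

In this assay compound 3 gives > 100000 nM, which is a limit of the assay and not a number. Putting 2-hydroxy-2-phenylpropyl in place of oxolan-2-yl gives an at least 9.5-fold higher number from compound 2 to compound 3 (0.97 log units; beyond the scatter), so a change on this carbonyl carbon can also raise the number sharply. The other comparison, an at least 1.4-fold higher number from compound 1 to compound 3 (0.16 log units; that floor lies within the scatter), gives only a floor and does not firmly separate the two compounds.

From the compounds shown here alone, the hydroxyl and the aromatic ring enter together, so their separate contributions remain open. Also open, going by these compounds, is whether a benzyl group without the hydroxyl, or an amine, would keep the number near that of compound 2.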